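A Small Change on the Amide Nitrogen of Compound 2

A few compounds are considered here, and "the series" means these few. Any claim that something is new, unique, unknown or untested is made for them only; others in the source may bear on it.

Within the data shown here, compound 2 `CCN(CC)c1ccc2cc(C(=O)NO)c(=O)oc2c1` gives 37600 nM in a functional assay on HCT-116 cells (Homo sapiens) for cytotoxicity, read by MTT assay, with a stated time of 72 h (on this read-out higher numbers stand for weaker inhibition and lower numbers for stronger inhibition), the only number among the values shown. Compound 1 `CCN(CC)c1ccc2cc(C(=O)NC(C)C)c(=O)oc2c1` reaches only a limit of this assay, > 100000 nM. Among the measured compounds shown here, the one measured step, an at least 2.6-fold lower number from compound 1 to compound 2 (0.42 log units; beyond the scatter), concerns the same amide nitrogen; it is beyond the scatter, but its full size is unknown because of the limit of > 100000 nM in this assay, at which 1 of the 2 values shown sits. Compound 3 `CCN(CC)c1ccc2cc(C(=O)NN)c(=O)oc2c1` differs from compound 2 by amino in place of hydroxy on an amide-type nitrogen. The step is expected to stay within the scatter or rise slightly, a 1.5-fold higher number from compound 2 to compound 3 (0.17 log units; within the scatter). Compound 3 is therefore estimated at 55000 nM in this assay, between 15000 nM and 200000 nM.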

Compound 3, half-maximal inhibitory concentration: 3360 nM
Beside the measured number, compound 3's estimate is 16-fold (1.21 log units) above it; the whole stated range lies above it.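

Amino in place of hydroxy on the amide-type nitrogen gives an 11-fold lower number from compound 2 to compound 3 (1.05 log units; beyond the scatter) in this assay. At this position, then, two groups with matching computed counts of heavy atoms, hydrogen-bond donors and hydrogen-bond acceptors are far from interchangeable. Amino in place of isopropyl gives an at least 29-fold lower number from compound 1 to compound 3 (1.47 log units; beyond the scatter), a step whose full size remains unknown: the limit of > 100000 nM in this assay, at which 1 of the 3 values shown sits.

Going by these compounds, whether methylamino or dimethylamino on this nitrogen would keep the number of compound 3 remains open. So does whether the step from hydroxy to amino would hold on a core other than the shared one.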